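The source may report more compounds than this note shows. Statements on the series, on what has been measured and on what is new or still open speak of the compounds shown alone.

Working notes on the series. Compound 1 `CCOC(=O)c1sc(N2C(=O)CSC2c2cccc(C(=O)NCCCCn3cccn3)c2)nc1C`, compound 2 `Cc1ccnc(N2C(=O)CSC2c2cccc(C(=O)NCCCCn3cccn3)c2)c1` and compound 3 `O=C(NCCCCn1cccn1)c1cccc(C2SCC(=O)N2c2cccc(C3CC3)c2)c1` share one core and differ only in the group on an amide-type nitrogen in a ring. In a functional assay on HOS-TE85 cells (Homo sapiens) for inhibition, read by CCK-8 assay, with a stated time of 72 h (a higher number here means a weaker inhibitor, a lower number a stronger inhibitor), compound 1 gives 430 nM, compound 2 gives 19.6 nM and compound 3 gives 299 nM. Compound 3 therefore stands second highest of the three numbers: the gap to compound 1 is small, a 1.4-fold lower number from compound 1 to compound 3 (0.16 log units; within the scatter), whereas the gap to compound 2 is large, a 15-fold higher number from compound 2 to compound 3 (1.18 log units; beyond the scatter).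

Among the measured compounds shown here, the next compound, compound 4 `O=C(NCCCCn1cccn1)c1cccc(C2SCC(=O)N2c2cc(F)ccn2)c1`, keeps the core of compound 3 and changes only that same group: 4-fluoropyridin-2-yl in place of 3-cyclopropylphenyl on an amide-type nitrogen in a ring.

For the measured compounds named here, two measured steps bear on this change. The pyridinyl-for-cyclopropylphenyl exchange is the reverse of what was seen between compound 2 and compound 3, a 15-fold higher number from compound 2 to compound 3 (1.18 log units; beyond the scatter), and the pyridinyl group also gave the large drop a 22-fold lower number from compound 1 to compound 2 (1.34 log units; beyond the scatter) against the thiazolyl of compound 1. Going by the values given here, compound 4 carries 4-fluoropyridin-2-yl rather than 4-methylpyridin-2-yl, and no measured pair isolates that fluorine-for-methyl difference, so the size is less certain than the direction. A large step toward a lower number is expected, a 10-fold lower number from compound 3 to compound 4 (1.00 log units; beyond the scatter), roughly undoing the rise from compound 2 to compound 3. Compound 4 is estimated at 30 nM in this assay, with a range of 10 nM to 120 nM.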

Compound 4, half-maximal inhibitory concentration: 33.2 nM
For compound 4 the middle estimate is 1.1-fold (0.04 log units) below the measured one; low and high end bracket the measured number.
By their numbers in this assay, from the lowest: compounds 2 and 4 (each within the scatter of the next); then compounds 3 and 1 (each within the scatter of the next).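

In this assay, among the compounds shown here, the change of fluoro in place of methyl on an aromatic carbon gives the first direct comparison between two pyridinyl groups (a 1.7-fold higher number from compound 2 to compound 4 (0.23 log units; within the scatter)), and on these numbers 4-fluoropyridin-2-yl and 4-methylpyridin-2-yl cannot be told apart. The low number of compound 2 therefore does not depend on the methyl group, as 4-fluoropyridin-2-yl on the amide-type nitrogen in a ring also stands clearly apart from both 3-cyclopropylphenyl (a 9.0-fold lower number from compound 3 to compound 4 (0.95 log units; beyond the scatter)) and 5-(ethoxycarbonyl)-4-methyl-1,3-thiazol-2-yl (a 13-fold lower number from compound 1 to compound 4 (1.11 log units; beyond the scatter)). No supporting data bear on why these groups differ.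

The step from compound 3 to compound 4 exchanges the whole group, so the shown compounds do not separate the contribution of the ring nitrogen from that of the fluoro and cyclopropyl substituents, a question that 3-fluorophenyl or unsubstituted pyridin-2-yl would address. Going by these compounds, it also remains open how far this tolerance extends to other groups on the same ring, such as 4-chloropyridin-2-yl, 4-methoxypyridin-2-yl or 4-aminopyridin-2-yl.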